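A few compounds are considered here, and "the series" means these few. Any claim that something is new, unique, unknown or untested is made for them only; others in the source may bear on it.

Measured so far in an assay on isolated protein for inhibition of protein kinase C zeta type (Homo sapiens), with a stated time of 4 min, tested at 62.5 uM; on this read-out higher numbers stand for more inhibition at the one concentration tested (going by the name of the read-out) and lower numbers for less inhibition:
Compound 1 `CC(C)(C)C1=NN(c2ccc(Br)cc2)C(c2ccc(O)cc2)C1` gives 93.2% in this assay.
Compound 2 `Oc1ccc(C2CC(c3ccccc3O)=NN2c2ccc(Cl)cc2)cc1` gives 92% in this assay.
Compound 3 `Oc1ccc(C2CC(c3cccs3)=NN2c2ccc(Br)cc2)cc1` gives 95.2% in this assay.

Compound 2 carries the numerically smallest of the three figures, but its gap to compound 1 and its gap to compound 3 both lie within the usual scatter, so the three compounds cannot be told apart on these numbers.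

Compound 4 `Nc1ccc(C2=NN(c3ccc(Cl)cc3)C(c3ccc(O)cc3)C2)cc1` differs from compound 2 in one place: 4-aminophenyl in place of 2-hydroxyphenyl on a carbon with a double bond to nitrogen. Among the compounds with values here, the only measured step at the same place in the shared core is the exchange of tert-butyl for thiophen-2-yl, which gave a number 2 percentage points higher from compound 1 to compound 3 (within the scatter). Within the data shown here, that step is within the scatter, and it is the sole guide available. Among the measured compounds shown here, no step is therefore expected beyond the scatter, and the estimated change is a number 1 percentage points lower from compound 2 to compound 4 (within the scatter). Compound 4 is expected to give about 91%, with a likely range from 80% to 97%.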

Compound 4, a percentage reported as inhibition, at one concentration (the size of the read-out at that concentration, not a potency): 98%
The estimate for compound 4 lay 7 percentage points below the measured number, outside the stated range (above it).
By their numbers in this assay, from the lowest: compounds 2, 1, 3 and 4 (each within the scatter of the next).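

In this assay, the change at this carbon gives a number 6 percentage points higher from compound 2 to compound 4 (within the scatter). Within the data shown here, until now the only step at this position was from tert-butyl to thiophen-2-yl; this one shows that replacing one substituted phenyl group with another, which exchanges a hydroxyl for an amine and also moves the substituent around the phenyl ring, does not take the number beyond the scatter in this pair of compounds. Nothing available explains why the number holds across this change.

Because the substituent's identity and its place on the phenyl ring differ together, this step cannot separate the two, and a 2-aminophenyl or a 4-hydroxyphenyl group at this carbon would be needed to do so. From the compounds shown here alone, it also remains open how a carboxylic acid or a longer alkyl chain at this carbon would read, and a figure at one concentration gives no potency.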